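The compounds below may be only part of what the source reports. "The series", "measured", "known", "first", "only" and "open" are said of these compounds alone.

Working notes on the series

Three compounds of the shared core carry the same dichloropyridyl urea hydrazide arm and differ at one aromatic carbon. Compound 1 `Cc1c(Cc2ccccc2)c(NNC(=O)Nc2cc(Cl)nc(Cl)c2)nc2c1cnn2C` carries a benzyl group there; in an assay on isolated protein for binding affinity to sphingosine 1-phosphate receptor 2 (Homo sapiens), read by surface plasmon resonance (on this read-out lower numbers stand for tighter binding and higher numbers for weaker binding), compound 1 gives 870 nM. Compound 2 `Cc1nn(C)c2nc(NNC(=O)Nc3cc(Cl)nc(Cl)c3)cc(-c3ccc(Cl)s3)c12` carries a 5-chlorothiophen-2-yl and in this assay compound 2 gives 1980 nM. Compound 3 `Cc1nn(C)c2nc(NNC(=O)Nc3cc(Cl)nc(Cl)c3)cc(-c3ccc(F)cc3)c12` carries a 4-fluorophenyl and in this assay compound 3 gives 980 nM.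

Compound 3 stands second highest of the three numbers. Its nearest neighbour is compound 1, whose value lies within the scatter of its own; its furthest is compound 2, which sits beyond the scatter. Going by the values given here, the one step that is resolved, a 2.0-fold lower number from compound 2 to compound 3 (0.31 log units; beyond the scatter), is the only measured change at this position.

Compound 4 `Cc1nn(C)c2nc(NNC(=O)Nc3cc(Cl)nc(Cl)c3)cc(-c3ccco3)c12` is not yet measured. The change is furan-2-yl in place of 4-fluorophenyl on an aromatic carbon. Among the compounds with values here, the only step that bears on it is a 2.0-fold lower number from compound 2 to compound 3 (0.31 log units; beyond the scatter): there a five-membered ring with one hetero atom gave the higher number and the six-membered carbon ring the lower one. Furan-2-yl is again a five-membered ring with one hetero atom, but it lacks the chlorine and its hetero atom differs, so the evidence is thin. A modest move towards weaker binding, or none beyond the scatter, is expected: a 1.4-fold higher number from compound 3 to compound 4 (0.15 log units; within the scatter).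

Compound 4 is estimated at 1400 nM, within a range of 500 nM to 4000 nM.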

Compound 4, dissociation constant: 6520 nM
Estimate against measurement, compound 4: 4.7-fold (0.67 log units) below, and the stated range ends below it.
By their numbers in this assay, from the lowest: compounds 1 and 3 (each within the scatter of the next); then compound 2; then compound 4.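

The furan-2-yl group turns out to be the poorest of the three aromatic groups carried at this carbon in this assay, with the largest step yet seen there (a 6.7-fold higher number from compound 3 to compound 4 (0.82 log units; beyond the scatter)) and a clear separation from the other five-membered ring as well (a 3.3-fold higher number from compound 2 to compound 4 (0.52 log units; beyond the scatter)). Both five-membered rings with one hetero atom therefore give higher numbers than 4-fluorophenyl, but ring size alone does not fix the value, since the two differ from each other by more than the scatter. No measurement here accounts for either step, and nothing is available to explain why furan-2-yl gives the highest number of the series.

The step between the two five-membered rings changes both the hetero atom and the ring chlorine, so the shown compounds cannot separate the contribution of each; thiophen-2-yl and 5-chlorofuran-2-yl would divide that step into its two parts. Going by these compounds, likewise, the part played by the fluorine in 4-fluorophenyl remains open, and plain phenyl would bear directly on it.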